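Swapping chloro for hydrogen on compound 2

A few compounds are considered here, and "the series" means these few. Any claim that something is new, unique, unknown or untested is made for them only; others in the source may bear on it.

Compound 1 (`Cc1cccc(-c2nn(-c3ccccc3)cc2C(Nc2nc3ccccc3s2)c2c(O)ccc3ccccc23)c1`) gives 17300 nM
Compound 2 (`COc1ccc2nc(NC(c3cn(-c4ccccc4)nc3-c3ccc(Cl)cc3)c3c(O)ccc4ccccc34)sc2c1`) gives 23700 nM

Among the compounds with values here, both numbers come from a functional assay on MCF7 cells (Homo sapiens) for antiproliferative activity, read by MTT assay, with a stated time of 48 h (on this read-out lower numbers stand for stronger inhibition and higher numbers for weaker inhibition), and, with only two compounds measured, they offer a small basis for prediction. Compound 2 at 23700 nM stands within the usual scatter of compound 1 at 17300 nM and so cannot be ranked against it.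

The next compound, compound 3 (`COc1ccc2nc(NC(c3cn(-c4ccccc4)nc3-c3ccccc3)c3c(O)ccc4ccccc34)sc2c1`), has not yet been measured. Its structure differs from that of compound 2 in a single place: hydrogen in place of chloro on an aromatic carbon Put simply, hydrogen takes the place of chloro on an aromatic carbon, which turns a 4-chlorophenyl group into phenyl.

Within the data shown here, no measured pair of compounds shows what a single change of this kind does, so the data offer no direct guide. The two values in hand sit close together and give no sign of a large step. The expected 1.1-fold lower number from compound 2 to compound 3 (0.05 log units; within the scatter) is estimated to stay within the usual scatter of this assay and has no firm direction. Compound 3 is therefore expected near 21000 nM (estimated range 9000 nM to 45000 nM).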

Compound 3, half-maximal inhibitory concentration: 40800 nM
Compound 3: middle estimate off by 1.9-fold (0.29 log units), on the low side; low and high end bracket the measured number.
By their numbers in this assay, from the lowest: compounds 1, 2 and 3 (each within the scatter of the next, the first and the last beyond it).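

Within the data shown here, this is the first pair of compounds that differ in a single place, so it gives the first direct reading of a change at this position. In this assay, replacing the chloro of the 4-chlorophenyl group with hydrogen gives a 1.7-fold higher number from compound 2 to compound 3 (0.24 log units; within the scatter) and is a step that cannot be told apart from repeat-to-repeat variation, so this pair does not show that the chloro matters for the read-out, nor that it does not. Nothing available explains the step or shows what the chloro does in these cells.

Among these compounds, a single pair also cannot show whether this position tolerates change in general, since chloro and hydrogen are only two of the many groups that could sit on this aromatic carbon. From the compounds shown here alone, whether a larger or differently built group, such as a methoxy, an amine or a carboxylic acid, would give a step beyond the scatter remains open, as does whether the swap from chloro to hydrogen would read the same on a different core.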